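Swapping Chloro for a Piperidine Ring: Expected Growth Inhibition

A few compounds are considered here, and "the series" means these few. Any claim that something is new, unique, unknown or untested is made for them only; others in the source may bear on it.

Of the compounds shown here, three sharing one core have been tested in a functional assay on SK-BR-3 cells (Homo sapiens) for inhibition, read by MTT assay, with a stated time of 2 days, tested at 100 uM; on this read-out higher numbers stand for more inhibition of growth at the one concentration tested and lower numbers for less inhibition of growth. Compound 1 `CNC(=O)c1cc(Oc2ccc3nc(NC(=O)c4ccc(Cl)cc4Cl)sc3c2)ccn1` gives 81%, compound 2 `CNC(=O)c1cc(Oc2ccc3nc(NC(=O)Nc4ccc(N5CCN(C)CC5)cc4)sc3c2)ccn1` gives 86.4%, and compound 3 `CNC(=O)c1cc(Oc2ccc3nc(NC(=O)Nc4ccc(Cl)cc4)sc3c2)ccn1` gives 77.4%. Compound 3 sits within the scatter of both others, as a number 3.6 percentage points lower from compound 1 to compound 3 (within the scatter) and a number 9 percentage points lower from compound 2 to compound 3 (within the scatter) show. Compound 4 `CNC(=O)c1cc(Oc2ccc3nc(NC(=O)Nc4ccc(C5CCN(C(C)C)CC5)cc4)sc3c2)ccn1` differs from compound 3 by 1-isopropylpiperidin-4-yl in place of chloro on an aromatic carbon. Within the data shown here, the only earlier step at that place, a number 9 percentage points lower from compound 2 to compound 3 (within the scatter), exchanged 4-methylpiperazin-1-yl for chloro and stayed within the scatter; the move to compound 4 runs the other way, putting 1-isopropylpiperidin-4-yl onto that aromatic carbon. The step from compound 3 to compound 4 is therefore expected to be a number 6.6 percentage points higher from compound 3 to compound 4 (within the scatter), a small rise inside the scatter. Compound 4 is estimated at 84%, between 72% and 94%.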

Compound 4, percent growth inhibition at one concentration: 91.6%
Compound 4: the middle estimate sits 7.6 percentage points below what was measured; the measured number falls inside the stated range.
By their numbers in this assay, from the lowest: compounds 3, 1, 2 and 4 (each within the scatter of the next, the first and the last beyond it).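

In this assay, replacing chloro on this aromatic carbon now gives a number 14.2 percentage points higher from compound 3 to compound 4 (beyond the scatter), a step beyond the scatter, which the earlier step at this place, involving 4-methylpiperazin-1-yl, did not give. Exchanging the two ring groups gives a number 5.2 percentage points higher from compound 2 to compound 4 (within the scatter), which stays within the scatter, so this read-out does not separate 1-isopropylpiperidin-4-yl from 4-methylpiperazin-1-yl here. No evidence at hand explains the rise over chloro.

Still open, on these data alone, is how a simple dimethylamino group or a carboxylic acid on this same aromatic carbon would compare with these ring groups.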